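Working notes: butoxy in place of hydrogen on compound 1

This account rests on a few compounds, and the source may have more. Where it says the series, first, only, none or still open, it means among the compounds named here.

Values in a functional assay on TSGH 8302 cells (Homo sapiens) for cytotoxicity; a lower number here means a stronger inhibitor, a higher number a weaker inhibitor:
- compound 1 `O=S(=O)(N/C(=N\O)Nc1ccc(Cl)cc1)c1ccccc1`: 52 ug/mL
- compound 2 `O=S(=O)(N/C(=N\O)Nc1ccc(Cl)cc1)c1cc2ccccc2s1`: 76 ug/mL
- compound 3 `O=S(=O)(N/C(=N\O)Nc1ccc(Cl)cc1)c1cccc2snnc12`: 93 ug/mL

On these numbers compound 1 is not separated from compound 2 or compound 3, since all three values lie within the scatter of one another. Among the compounds with values here, no pair of measured compounds differs in one place only, so the series offers no direct step to read.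

Compound 4 `CCCCOc1ccc(S(=O)(=O)N/C(=N\O)Nc2ccc(Cl)cc2)cc1` keeps the core of compound 1 and carries butoxy in place of hydrogen on an aromatic carbon, para to a large group (butoxy in place of hydrogen on an aromatic carbon). Within the data shown here, no measured compound carries this change.

Compound 2 at 76 ug/mL and compound 3 at 93 ug/mL both sit within the scatter of compound 1 at 52 ug/mL, so a small step toward a lower number in this assay is expected, probably not beyond the scatter. The estimated step is a 1.5-fold lower number from compound 1 to compound 4 (0.17 log units; within the scatter). For compound 4 the expected value is 35 ug/mL, with an estimated range of 12 ug/mL to 90 ug/mL.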

Compound 4, half-maximal inhibitory concentration: 37 ug/mL
Beside the measured number, compound 4's estimate is 1.1-fold (0.02 log units) below it; low and high end bracket the measured number.
By their numbers in this assay, from the lowest: compounds 4, 1, 2 and 3 (each within the scatter of the next, the first and the last beyond it).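

In this assay the series now has its first one-place step, a 1.4-fold lower number from compound 1 to compound 4 (0.15 log units; within the scatter) for butoxy in place of hydrogen on an aromatic carbon, para to a large group. The position therefore accepts this chain, which adds no ring and no net charge, without separating compound 4 from compound 1 in this read-out. No available evidence accounts for this result.

The compounds shown leave open whether any group at this position can move the value beyond the scatter, since a single step gives no trend along a chain or across group types. Methoxy, a longer alkoxy chain, an amine or a carboxylic acid at the same place would show whether this position responds to change or stays flat.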